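Swapping 2,4-dichlorophenyl for 4-cyanophenyl on a shared core

The source may hold more compounds than are shown below. What is called first, only, known or untested is meant among the compounds shown, and "the series" means these compounds.

- compound 1 `COc1cc(/C=C2\CN(C)C/C(=C\c3ccccc3F)C2=O)cc(OC)c1` gives 1240 nM
- compound 2 `COc1cc(/C=C2\CN(C)C/C(=C\c3ccc(F)cc3)C2=O)cc(OC)c1` gives 6140 nM
- compound 3 `COc1cc(/C=C2\CN(C)C/C(=C\c3ccc(Cl)cc3Cl)C2=O)cc(OC)c1` gives 6250 nM

All three numbers come from a functional assay on HepG2 cells (Homo sapiens) for cytotoxicity, read by MTT assay, with a stated time of 24 h (on this read-out lower numbers stand for stronger inhibition and higher numbers for weaker inhibition), and differ only in one aromatic group. Compound 3 sits level with compound 2 within the usual scatter, and both carry clearly higher numbers than compound 1. Compound 4 `COc1cc(/C=C2\CN(C)C/C(=C\c3ccc(C#N)cc3)C2=O)cc(OC)c1` keeps the shared core and changes that one group, with 4-cyanophenyl in place of 2,4-dichlorophenyl on a double-bonded chain carbon bound to a double-bonded ring carbon on the same double-bonded chain carbon bound to a double-bonded ring carbon.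

For the measured compounds named here, three measured steps bear on this. Going by the values given here, two are modest and both start from the 2-fluorophenyl group: a 5.0-fold higher number from compound 1 to compound 2 (0.69 log units; beyond the scatter) and a 5.0-fold higher number from compound 1 to compound 3 (0.70 log units; beyond the scatter) are the only changes beyond the scatter. The third, a 1.0-fold higher number from compound 2 to compound 3 (0.01 log units; within the scatter) shows two different groups reading alike. Among the compounds with values here, no measured compound carries a nitrile, so the evidence is indirect. Since compound 2 gives 6140 nM with 4-fluorophenyl, the closest group by name, no step beyond the scatter is expected in this assay here. The estimated change is a 1.3-fold lower number from compound 3 to compound 4 (0.10 log units; within the scatter) and it could still prove larger. For compound 4 the estimated value is 5000 nM with an expected range from 1800 nM to 14000 nM as its two ends.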

Compound 4, half-maximal inhibitory concentration: 880 nM
Compound 4: middle estimate off by 5.7-fold (0.75 log units), on the high side, and the stated range ends above it.
By their numbers in this assay, from the lowest: compounds 4 and 1 (each within the scatter of the next); then compounds 2 and 3 (each within the scatter of the next).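

In this assay, the group on the double-bonded chain carbon bound to a double-bonded ring carbon can reach the low end of the range with something other than 2-fluorophenyl: 4-cyanophenyl in place of 2,4-dichlorophenyl gives a 7.1-fold lower number from compound 3 to compound 4 (0.85 log units; beyond the scatter) and cyano in place of fluoro gives a 7.0-fold lower number from compound 2 to compound 4 (0.84 log units; beyond the scatter) in a single exchange. For the compounds shown here, the earlier compounds showed only one group at the low end, whereas 4-cyanophenyl now reads level with 2-fluorophenyl, with a 1.4-fold lower number from compound 1 to compound 4 (0.15 log units; within the scatter) as the step between them. No measurement shown here explains why these groups differ.

From the compounds shown here alone, whether the low number is special to the nitrile remains open, since only four aromatic groups appear here. A carboxylic acid or an amine on the same phenyl ring could read either way.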